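The source may report more compounds than this note shows. Statements on the series, on what has been measured and on what is new or still open speak of the compounds shown alone.

Of the compounds shown here, two with a shared core have been measured in an ADME assay on HaCaT cells (Homo sapiens) for cytotoxicity, read by MTT assay, with a stated time of 48 h; a higher number here means a weaker inhibitor, a lower number a stronger inhibitor. Compound 1 `COc1ccc2[nH]c(-c3cn(-c4ccccc4)nc3-c3ccc(F)cc3)nc2c1` gives > 50000 nM, which is a limit of the assay and not a number. Compound 2 `Fc1ccc(-c2nn(-c3ccccc3)cc2-c2nc3cc(C(F)(F)F)ccc3[nH]2)cc1` gives > 50000 nM, again a limit and not a number. Compound 2 therefore has no exact value, and the only other result beside it is also a limit. The data show (the limit of > 50000 nM in this assay, at which 2 of the 2 values shown sit). Going by the values given here, the one measured step is a step that the two limits leave unreadable from compound 1 to compound 2, with trifluoromethyl in place of methoxy on an aromatic carbon, so it offers no size to carry forward.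

Compound 3 `FC(F)(F)c1ccc2[nH]c(-c3cn(-c4ccccc4)nc3-c3ccc(Cl)cc3)nc2c1` keeps the trifluoromethyl group and differs from compound 2 elsewhere: chloro in place of fluoro on an aromatic carbon. This is chloro in place of fluoro on an aromatic carbon, 4-fluorophenyl to 4-chlorophenyl. Among the compounds with values here, no measured step covers this change. Within the data shown here, no step beyond the scatter is therefore expected in this assay, in either direction, and the only anchor is compound 2 with its limit of > 50000 nM. The expected change is a number no higher from compound 2 to compound 3 (the limit leaves the size open). For compound 3 the estimated value is 50000 nM, with an expected range from 20000 nM to 100000 nM.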

Compound 3, half-maximal inhibitory concentration: 41800 nM
The estimate for compound 3 lay 1.2-fold (0.08 log units) above the measured number, within the range that was stated.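

In this assay, going by these compounds alone, compound 3 gives 41800 nM, the first exact number, with chloro in place of fluoro on an aromatic carbon of a six-membered aromatic ring of carbon only, para to a large group. From the compounds shown here alone, the change from 4-fluorophenyl to 4-chlorophenyl reads as an at least 1.1-fold lower number from compound 2 to compound 3 (0.07 log units; that floor lies within the scatter), which is a floor only, so its true size stays open and it does not establish a real difference at this position. Compound 1 and compound 2 remain at a limit of the assay and not at a number, and the step between them cannot be read: the limit of > 50000 nM in this assay, at which 2 of the 3 values shown sit.

The compounds shown leave open how a bromo group or an amine at this position would read in this assay. They also leave open whether chloro at this position would give an exact number with methoxy in place of trifluoromethyl on the shared core, or with a carboxylic acid there.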